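Trifluoromethoxy for methoxy in a quinolinyl urea pair

The compounds below may be only part of what the source reports. "The series", "measured", "known", "first", "only" and "open" are said of these compounds alone.

Compound 2 `COc1ccccc1NC(=O)Nc1cc(C)nc2ccccc12` and compound 1 `Cc1cc(NC(=O)Nc2ccccc2OC(F)(F)F)c2ccccc2n1` share one core; compound 3 `COc1cccc(NC(=O)Nc2cc(C)nc3ccccc23)c1` and compound 4 `Cc1cc(NC(=O)Nc2cccc(OC(F)(F)F)c2)c2ccccc2n1` share another, and the difference between the two cores is not broken down here. In a physicochemical assay for solubility, at pH 7.4 (on this read-out higher numbers stand for higher solubility and lower numbers for lower solubility), compound 2 gives 100 nM, while compound 1 gives 4600 nM. The change from compound 2 to compound 1 is trifluoromethyl in place of methyl on an oxygen on an aromatic ring, and it made a 46-fold higher number from compound 2 to compound 1 (1.66 log units; beyond the scatter). Compound 3 gives 1200 nM in this assay, which stands between the other two values. Compound 4 is not yet measured; it differs from compound 3 by trifluoromethyl in place of methyl on an oxygen on an aromatic ring, the same change as before, made at the same kind of place. Carried over from the one measured instance, the step from compound 3 to compound 4 is expected to be about a 25-fold higher number from compound 3 to compound 4 (1.40 log units; beyond the scatter), resting on the size of a 46-fold higher number from compound 2 to compound 1 (1.66 log units; beyond the scatter) with a wide margin because only one pair supports it. Compound 4 is therefore estimated at 30000 nM in this assay, within 8000 nM to 120000 nM.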

Compound 4, solubility: 600 nM
Estimate against measurement, compound 4: 50-fold (1.70 log units) above; measured number below the stated range.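

In this assay, methoxy to trifluoromethoxy gives a 2.0-fold lower number from compound 3 to compound 4 (0.30 log units; within the scatter) and so does not repeat a 46-fold higher number from compound 2 to compound 1 (1.66 log units; beyond the scatter) in the other core. The large step seen in the core of compound 2 therefore does not carry over to the core of compound 3, and its size cannot be treated as a property of this change alone across the series. Two pairs show only that the outcome can depend on the core, not how it depends on it or which of the two pairs is more typical, and no measurement shown bears on the reason for the difference.

The compounds shown leave open how the change reads on any further core, since a third matched pair would be needed to tell whether either step is the usual one. They also leave open how a longer chain such as ethyl on the same oxygen, or an amine or a carboxylic acid in place of the methoxy, would read in this assay on either core.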